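From compound 3 to compound 4: the side group exchanged

This account rests on a few compounds, and the source may have more. Where it says the series, first, only, none or still open, it means among the compounds named here.

In a functional assay on T98G cells (Homo sapiens) for inhibition, read by MTT assay, with a stated time of 72 h (on this read-out higher numbers stand for weaker inhibition and lower numbers for stronger inhibition), compound 1 `CC1(C)CC(NC(=O)Nc2ccccc2)c2cc(Cl)ccc2O1` gives 34000 nM and compound 2 `CC(C)NC(=S)NC1CC(C)(C)Oc2ccc(Cl)cc21` gives 91000 nM. Compound 3 `CCNC(=S)NC1CC(C)(C)Oc2ccc(Cl)cc21` gives > 100000 nM, which is a limit of the assay and not a number. For the measured compounds named here, the one measured step, an at least 1.0-fold higher number from compound 2 to compound 3 (0.04 log units; that floor lies within the scatter), is only a floor and stays within the scatter.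

Compound 4 `CC(C)NC(=O)NC1CC(C)(C)Oc2ccc(Cl)cc21` departs from compound 3 by a group of 6 heavy atoms (4 carbon, 1 nitrogen, 1 oxygen; no ring) in place of a group of 5 heavy atoms (3 carbon, 1 nitrogen, 1 sulfur; no ring), on an amine nitrogen. In words, isopropylcarbamoyl replaces a group of 5 heavy atoms on an amine nitrogen. Going by the values given here, no measured step isolates this exchange, so the evidence is indirect. Compound 2 sits close to the top of the range at 91000 nM, and compound 1, which also carries a carbonyl, reads 34000 nM. Together these values suggest a number under the limit, though not far under it. A modest move towards stronger inhibition is expected, as an at least 1.5-fold lower number from compound 3 to compound 4 (0.18 log units; that floor lies within the scatter). For compound 4 the estimate is 65000 nM, with an expected range of 30000 nM to 100000 nM.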

Compound 4, half-maximal inhibitory concentration: > 100000 nM
Compound 4: a limit, no number; the forecaster's own chance of this, stated with the estimate: 30%; middle value at least 1.5-fold (0.18 log units) from the limit.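

In this assay compound 4 gives > 100000 nM, which is a limit of the assay and not a number, and the step from compound 3 cannot be read: the limit of > 100000 nM in this assay, at which 2 of the 4 values shown sit.

The one clear signal comes from the group on the amide-type nitrogen: with isopropyl in place of phenyl there is an at least 2.9-fold higher number from compound 1 to compound 4 (0.46 log units; beyond the scatter), so within this pair the phenyl-bearing compound gives the stronger inhibition. With isopropyl kept, the exchange of the sulfur-containing group for the oxygen-containing one gives only an at least 1.0-fold higher number from compound 2 to compound 4 (0.04 log units; that floor lies within the scatter), a floor that supports no statement on that exchange.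

The compounds shown leave open whether phenyl keeps this edge with sulfur in the group in place of oxygen. They also leave open how a benzyl group, a 4-chlorophenyl group or a longer chain on that nitrogen would read.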